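The source may report more compounds than this note shows. Statements on the series, on what has been measured and on what is new or still open speak of the compounds shown alone.

Working notes on the series

The shared core is that of compound 1 `COc1ccc(-c2cnc(NC(=O)c3cccc(OC)c3)n2C)cc1`, with the group on the carbonyl carbon varied across the set. In a toxicity assay on THP-1 cells (Homo sapiens) for inhibition (on this read-out higher numbers stand for lower toxicity in this test and lower numbers for higher toxicity in this test), compound 1 gives only a limit, > 100000 nM. Compound 2 `COc1ccc(-c2cnc(NC(=O)c3ccccc3Br)n2C)cc1` carries 2-bromophenyl in place of 3-methoxyphenyl on a carbonyl carbon; in this assay compound 2 likewise gives a limit, > 100000 nM. Compound 3 `COc1ccc(-c2cnc(NC(=O)c3ccc(Cl)cc3)n2C)cc1` carries 4-chlorophenyl in place of 3-methoxyphenyl on a carbonyl carbon; in this assay compound 3 also gives a limit, > 100000 nM. The steps among these three are a step that the two limits leave unreadable from compound 1 to compound 2, a step that the two limits leave unreadable from compound 1 to compound 3 and a step that the two limits leave unreadable from compound 2 to compound 3; none of them can be sized, because of the limit of > 100000 nM in this assay, at which 3 of the 3 values shown sit. Compound 3 thus stands at the limit, together with the two other values.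

Compound 4 `COc1ccc(-c2cnc(NC(C)=O)n2C)cc1` is the next member to be measured. It differs from compound 3 in one place: methyl in place of 4-chlorophenyl on a carbonyl carbon. For the measured compounds named here, no measured step trades a substituted phenyl for methyl, so the three unreadable steps show only that the variations so far have kept every compound at the limit. The expected step is a step that the limit leaves unreadable from compound 3 to compound 4, and the most likely outcome is again a limit rather than a number. In this assay compound 4 is therefore estimated at 150000 nM, within 50000 nM to 500000 nM.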

Compound 4, half-maximal cytotoxic concentration: > 100000 nM
Compound 4 gave a limit, no number; the forecaster's own chance of this, stated with the estimate: 85%; the middle value does not contradict the limit.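

Compound 4 gives only a limit in this assay, and its steps from compound 1, compound 2 and compound 3 cannot be read, because all four compounds stand at the same limit: the limit of > 100000 nM in this assay, at which 4 of the 4 values shown sit.

The compounds shown leave open whether any group on the carbonyl carbon of the shared core gives a measurable half-maximal cytotoxic concentration in this assay.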